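From a Methoxy Carbamate to a Morpholine Urea

This account rests on a few compounds, and the source may have more. Where it says the series, first, only, none or still open, it means among the compounds named here.

Of the compounds shown here, three have been measured in an assay on COS-7 cells for inhibition of patatin-like phospholipase domain-containing protein 2 (Mus musculus), tested at 200 uM; on this read-out lower numbers stand for less inhibition and higher numbers for more inhibition at the one concentration tested (going by the name of the read-out). Compound 1 `CCOC(=O)c1cccc(-c2ccc(OC)cc2)c1` gives 77%, compound 2 `CCOC(=O)c1cccc(-c2ccc(OCC)nc2)c1` gives 68%, and compound 3 `COC(=O)Nc1cccc(-c2ccc(N(C)C)cc2)c1` gives 95%, the highest of the three and beyond the scatter above both other numbers. Compound 4 `CN(C)c1ccc(-c2cccc(NC(=O)N3CCOCC3)c2)cc1` has not yet been tested. It differs from compound 3 in one place: morpholin-4-yl in place of methoxy on a carbonyl carbon. Seen one bond further out, methoxycarbonyl becomes (morpholin-4-yl)carbonyl. Among the measured compounds shown here, no measured pair shows this change, so its effect can only be estimated. Since compound 3 already sits near the top of the scale with 95%, the expected step of a number 10 percentage points lower from compound 3 to compound 4 (within the scatter) is a small fall, at most just beyond the scatter. Compound 4 is therefore expected to give about 85%, with a likely range from 65% to 98%.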

Compound 4, a percentage reported as inhibition, at one concentration (the size of the read-out at that concentration, not a potency): 31%
Beside the measured number, compound 4's estimate is 54 percentage points above it; the whole stated range lies above it.
By their numbers in this assay, from the lowest: compound 4; then compounds 2 and 1 (each within the scatter of the next); then compound 3.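

In this assay, among the compounds shown here, morpholin-4-yl in place of methoxy on a carbonyl carbon gives a number 64 percentage points lower from compound 3 to compound 4 (beyond the scatter), so this single place has a large effect on the read-out, something the earlier compounds could not show. The counts of hydrogen-bond donors and acceptors in the two groups are the same, so those counts do not follow this fall. Nothing measured here gives a reason for it. As far as these compounds go, whether the fall belongs to the ring or to the oxygen within it stays open. Piperidin-1-yl or diethylamino on that carbonyl carbon would help separate these.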